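A few compounds are considered here, and "the series" means these few. Any claim that something is new, unique, unknown or untested is made for them only; others in the source may bear on it.

Measured so far: compound 1 `Cc1cccc(-n2nc(-c3ccccc3)c(C=O)c2/N=C/N(C)C)c1` gives 9700 nM in a functional assay on Jurkat cells (Homo sapiens) for inhibition, read by MTT assay, with a stated time of 72 h; on this read-out lower numbers stand for stronger inhibition of growth and higher numbers for weaker inhibition of growth; compound 2 `CN(C)/C=N/c1c(C=O)c(-c2ccccc2)nn1-c1cccc(Cl)c1` gives 8300 nM; compound 3 `Cc1ccc(-c2nn(-c3ccccc3)c(/N=C/N(C)C)c2C=O)cc1` gives 9500 nM.

Compound 1 and compound 2 differ by chloro in place of methyl on an aromatic carbon, and this step reads a 1.2-fold lower number from compound 1 to compound 2 (0.07 log units; within the scatter). The core of compound 3 differs from the core of compound 1, but that difference is not broken down here. Compound 4 `CN(C)/C=N/c1c(C=O)c(-c2ccc(Cl)cc2)nn1-c1ccccc1` has not yet been measured; it differs from compound 3 by chloro in place of methyl on an aromatic carbon. This is the same kind of change as from compound 1 to compound 2, though the group now sits para to a large group rather than meta to a large group. Since the earlier step lies within the scatter, the step for compound 4 is expected to be small as well, about a 1.1-fold lower number from compound 3 to compound 4 (0.05 log units; within the scatter). Compound 4 is therefore estimated at 8500 nM, between 4000 nM and 18000 nM.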

Compound 4, concentration for 50% growth inhibition: 7900 nM
Beside the measured number, compound 4's estimate is 1.1-fold (0.03 log units) above it; the measured number falls inside the stated range.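

In this assay, chloro in place of methyl on the second core gives a 1.2-fold lower number from compound 3 to compound 4 (0.08 log units; within the scatter). Set beside the earlier step, the change reads the same on both cores: the same change on two cores in this assay, a 1.2-fold lower number (0.07 log units; within the scatter) from compound 1 to compound 2 and a 1.2-fold lower number (0.08 log units; within the scatter) from compound 3 to compound 4, 1.0-fold (0.01 log units) apart, within the scatter of two such steps

This shows that, on these two cores, the change stays within the scatter, but it shows no gain from chloro over methyl, and two small steps cannot show whether a larger effect would carry across cores in the same way. The compounds shown leave open how growth inhibition would respond to quite different groups on these aromatic rings, such as an amine or a carboxylic acid. They also leave open whether any change at all on these rings moves the number beyond the scatter.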